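Amino for Chloro on a Fused Core

A few compounds are considered here, and "the series" means these few. Any claim that something is new, unique, unknown or untested is made for them only; others in the source may bear on it.

compound 1 `ClCc1ccc(Cn2cnc3c(Cl)ncnc32)cc1`: 1280 nM
compound 2 `ClCc1ccccc1Cn1cnc2c(Cl)nc(Cl)nc21`: 1620 nM
compound 3 `ClCc1cccc(Cn2cnc3c(Cl)nc(Cl)nc32)c1`: 3710 nM

All three were tested in a functional assay on ACHN cells (Homo sapiens) for cytotoxicity, read by sulforhodamine B assay, with a stated time of 48 h; a lower number here means a stronger inhibitor of growth, a higher number a weaker inhibitor of growth. Compound 2 gives the second highest of the three numbers: compound 1 sits close to it, within the scatter, while compound 3 lies beyond the scatter from it. Compound 4 `Nc1nc(Cl)c2ncn(Cc3ccccc3CCl)c2n1` has not yet been measured. It differs from compound 2 in a single place: amino in place of chloro on an aromatic carbon. Among the measured compounds shown here, no pair of measured compounds differs by this kind of change, so there is no earlier step to lean on. In this assay a modest shift toward a higher number is expected, one that may well stay within the scatter. Compound 4 is estimated at 2000 nM, with a range from 700 nM to 6000 nM. That estimate amounts to a step of a 1.2-fold higher number from compound 2 to compound 4 (0.09 log units; within the scatter) and stays tentative.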

Compound 4, concentration for total growth inhibition: 21900 nM
Beside the measured number, compound 4's estimate is 11-fold (1.04 log units) below it, outside the stated range (above it).
By their numbers in this assay, from the lowest: compounds 1 and 2 (each within the scatter of the next); then compound 3; then compound 4.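

In this assay, replacing the chloro between two ring nitrogen atoms with amino gives a 14-fold higher number from compound 2 to compound 4 (1.13 log units; beyond the scatter), a large loss of growth inhibition. The earlier compounds shown here offered no single-place comparison, and this pair now shows that swapping one heavy atom at this position can matter greatly. Nothing available here explains the size of this step.

From the compounds shown here alone, whether a methoxy or a methylamino group here would behave more like chloro or like amino remains open. So does whether the same swap would cost as much with the chloromethyl group placed as in compound 3.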